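The source may report more compounds than this note shows. Statements on the series, on what has been measured and on what is new or still open speak of the compounds shown alone.

In a functional assay on HepG2 cells (Homo sapiens) for inhibition, read by MTT assay, with a stated time of 24 h (a higher number here means a weaker inhibitor of growth, a lower number a stronger inhibitor of growth), compound 1 (`COc1ccc(C(=O)n2c(-c3cn(C)c4ccccc34)nc3ccccc32)cc1`) gives 15200 nM and compound 2 (`Cn1cc(-c2nc3ccccc3n2C(=O)c2ccccc2Br)c2ccccc21`) gives 68200 nM as the higher of the two numbers. For the measured compounds named here, the only measured step, a 4.5-fold higher number from compound 1 to compound 2 (0.65 log units; beyond the scatter) with 2-bromophenyl in place of 4-methoxyphenyl on a carbonyl carbon, is modest. Compound 3 (`Cn1cc(-c2nc3ccccc3n2C(=O)c2cccc(Br)c2)c2ccccc21`) has the same atoms as compound 2, joined differently, with 3-bromophenyl in place of 2-bromophenyl on a carbonyl carbon. Going by the values given here, no measured step makes this change alone, so that modest size is only a loose guide. A somewhat smaller move toward a lower number is expected, estimated as a 2.3-fold lower number from compound 2 to compound 3 (0.36 log units; beyond the scatter) here. For compound 3, 30000 nM is the estimated value, with 12000 nM to 70000 nM as its expected range.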

Compound 3, concentration for 50% growth inhibition: 61400 nM
Beside the measured number, compound 3's estimate is 2.0-fold (0.31 log units) below it, and the stated range covers the measured number.
By their numbers in this assay, from the lowest: compound 1; then compounds 3 and 2 (each within the scatter of the next).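

In this assay, 3-bromophenyl in place of 2-bromophenyl on the carbonyl carbon gives a 1.1-fold lower number from compound 2 to compound 3 (0.05 log units; within the scatter), so these two bromophenyl groups cannot be told apart here. With 3-bromophenyl in place of 4-methoxyphenyl, the result is a 4.0-fold higher number from compound 1 to compound 3 (0.61 log units; beyond the scatter), so both bromophenyl compounds stand apart from compound 1. No supporting data explain these results. Still open, going by these compounds, is whether that gap follows the group itself or its place on the ring: 4-bromophenyl and 2-methoxyphenyl compounds could separate the two.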